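Quinoxaline sulfone anilines: halogen swap on the anilino ring

This account rests on a few compounds, and the source may have more. Where it says the series, first, only, none or still open, it means among the compounds named here.

Measured so far:
compound 1, `Cc1ccc(S(=O)(=O)c2nc3ccccc3nc2Nc2ccc(F)cc2)cc1`, 5100 nM
compound 2, `Cc1ccc(S(=O)(=O)c2nc3ccccc3nc2Nc2ccc(Cl)cc2)cc1`, 17500 nM
compound 3, `COc1ccc(S(=O)(=O)c2nc3ccccc3nc2Nc2ccc(F)cc2)cc1`, 610 nM

In a functional assay on HL-60 cells (Homo sapiens) for cytotoxicity, read by MTT assay, with a stated time of 72 h (on this read-out lower numbers stand for stronger inhibition and higher numbers for weaker inhibition), compound 3 gives the lowest number of the three. The change from compound 1 to compound 3 is methoxy in place of methyl on an aromatic carbon, and it made an 8.4-fold lower number from compound 1 to compound 3 (0.92 log units; beyond the scatter). The change from compound 1 to compound 2 is chloro in place of fluoro on an aromatic carbon, and it made a 3.4-fold higher number from compound 1 to compound 2 (0.54 log units; beyond the scatter).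

Compound 4, `COc1ccc(S(=O)(=O)c2nc3ccccc3nc2Nc2ccc(Cl)cc2)cc1`, is not yet measured. It differs from compound 3 by chloro in place of fluoro on an aromatic carbon, the same change as that from compound 1 to compound 2, made on the core of compound 3 rather than that of compound 1. Going by the values given here, the step expected from compound 3 to compound 4 in this assay is a 3.3-fold higher number from compound 3 to compound 4 (0.52 log units; beyond the scatter), set beside the earlier one because of a 3.4-fold higher number from compound 1 to compound 2 (0.54 log units; beyond the scatter), on the assumption that the two changes behave alike on the two cores, which only one pair supports. Compound 4 is therefore estimated at 2000 nM, expected between 800 nM and 5500 nM.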

Compound 4, half-maximal inhibitory concentration: 19600 nM
Estimate against measurement, compound 4: 9.8-fold (0.99 log units) below, outside the stated range (above it).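

In this assay, chloro in place of fluoro gives a 32-fold higher number from compound 3 to compound 4 (1.51 log units; beyond the scatter), so the direction of the halogen step carries from the core of compound 1 to the core of compound 3, but its size does not: the same change on two cores in this assay, a 3.4-fold higher number (0.54 log units; beyond the scatter) from compound 1 to compound 2 and a 32-fold higher number (1.51 log units; beyond the scatter) from compound 3 to compound 4, 9.4-fold (0.97 log units) apart, beyond the scatter of two such steps

Methoxy in place of methyl gives a 1.1-fold higher number from compound 2 to compound 4 (0.05 log units; within the scatter) with the 4-chlorophenyl group, so the methoxy step does not carry over from the 4-fluorophenyl compounds: the same change on two cores in this assay, an 8.4-fold lower number (0.92 log units; beyond the scatter) from compound 1 to compound 3 and a 1.1-fold higher number (0.05 log units; within the scatter) from compound 2 to compound 4, 9.4-fold (0.97 log units) apart, beyond the scatter of two such steps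

The two changes are therefore not additive across these four compounds, though this single set of pairs gives no reason for that and no rule for other cores.

From the compounds shown here alone, whether the low number of compound 3 depends specifically on fluoro and methoxy together remains open. A bromo or nitrile in place of the fluoro, or an ethoxy in place of the methoxy, could test this.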